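Adding a third methoxy to a chalcone-pyrazole pair

The compounds below may be only part of what the source reports. "The series", "measured", "known", "first", "only" and "open" are said of these compounds alone.

Compound 2 `COc1ccc(C(=O)/C=C/c2cc(-c3cc(OC)c(OC)c(OC)c3)n[nH]2)cc1OC` carries two methoxy groups on the ring attached to the carbonyl. Among the compounds with values here, in a functional assay on OVCAR-3 cells (Homo sapiens) for cytotoxicity, read by sulforhodamine B assay, with a stated time of 48 h, tested at 100 uM (a lower number here means a stronger effect, a higher number a weaker effect of the compound at the concentration tested), compound 2 gives -84%, the higher of the two numbers known so far; its nearest neighbour, compound 1 `COc1cc(-c2cc(/C=C/C(=O)c3ccc(N)cc3)[nH]n2)cc(OC)c1OC`, gives -93%, and the step of a number 9 percentage points higher from compound 1 to compound 2 (within the scatter) lies within the scatter. Compound 3 `COc1cc(C(=O)/C=C/c2cc(-c3cc(OC)c(OC)c(OC)c3)n[nH]2)cc(OC)c1OC` differs from compound 2 by methoxy in place of hydrogen on an aromatic carbon. Within the data shown here, no measured step involves such an addition, and the only known step concerned a different ring. Nothing therefore points to a change beyond the scatter, and the expected step of a number 1 percentage points lower from compound 2 to compound 3 (within the scatter) is essentially flat. Compound 3 is thus expected to give about -85%, within -97% to -68%.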

Compound 3, a percentage reported as activity, at one concentration (the size of the read-out at that concentration, not a potency): -98%
Compound 3: middle estimate off by 13 percentage points, on the high side; measured number outside the range, below it.
By their numbers in this assay, from the lowest: compounds 3, 1 and 2 (each within the scatter of the next, the first and the last beyond it).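

In this assay, methoxy in place of hydrogen on an aromatic carbon of the ring attached to the carbonyl gives a number 14 percentage points lower from compound 2 to compound 3 (beyond the scatter) in a modest step. Within the data shown here, this is the first measured sign that a change on this ring can move the number beyond the scatter, which the earlier step could not show. No available evidence explains the shift.

From the compounds shown here alone, whether this step is specific to methoxy stays open. Fluorine or hydroxyl on the same carbon would show whether other groups give a similar number.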